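This account rests on a few compounds, and the source may have more. Where it says the series, first, only, none or still open, it means among the compounds named here.

Measured so far in a functional assay on HepG2 cells (Homo sapiens) for antiproliferative activity, read by colorimetric assay and MTT assay, with a stated time of 48 h; on this read-out lower numbers stand for stronger inhibition and higher numbers for weaker inhibition:
Compound 1 `O=C(NS(=O)(=O)c1ccccc1)c1cccnc1` gives 10400 nM
Compound 2 `Cc1ccc(S(=O)(=O)NC(=O)c2cccnc2)cc1` gives 12300 nM
Compound 3 `O=C(NS(=O)(=O)c1ccc(Cl)cc1)c1ccncc1` gives 7900 nM
Compound 4 `Cc1ccc(S(=O)(=O)NC(=O)c2ccncc2)cc1` is not yet measured

Compound 3 stands within the scatter of both compound 1 and compound 2, so this assay does not separate the three. Going to compound 4 places methyl in place of chloro on an aromatic carbon. Within the data shown here, the one measured step that bears on this is a 1.2-fold higher number from compound 1 to compound 2 (0.07 log units; within the scatter), which places methyl in place of hydrogen. Among the measured compounds shown here, no measured step removes chloro, so this support is only partial. No step beyond the scatter is therefore expected in this assay. The expected step is a 1.3-fold higher number from compound 3 to compound 4 (0.10 log units; within the scatter) and no clear direction is implied. For compound 4 the estimated value is 10000 nM, with an expected range of 5000 nM to 20000 nM.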

Compound 4, half-maximal inhibitory concentration: 20200 nM
Beside the measured number, compound 4's estimate is 2.0-fold (0.31 log units) below it; the measured number lies above the stated range.
By their numbers in this assay, from the lowest: compounds 3, 1, 2 and 4 (each within the scatter of the next, the first and the last beyond it).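

In this assay, among these compounds, methyl in place of chloro on an aromatic carbon, para to a large group, gives a 2.6-fold higher number from compound 3 to compound 4 (0.41 log units; beyond the scatter) and is the first step to lie beyond the scatter, though only modestly. With methyl at this position, pyridin-4-yl in place of pyridin-3-yl on a carbonyl carbon gives a 1.6-fold higher number from compound 2 to compound 4 (0.22 log units; within the scatter) and so does not separate the two attachments. No measured evidence bears on the step from chloro to methyl.

Going by these compounds, it remains open whether this step holds with pyridin-3-yl on the carbonyl carbon, and how an amine or a carboxylic acid at the same position would read in this assay.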